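Chloro in place of methoxy: an expected cytotoxicity value

The source may hold more compounds than are shown below. What is called first, only, known or untested is meant among the compounds shown, and "the series" means these compounds.

Four compounds share one core and differ in two places. Compound 1 `COc1cc(-c2nnc3n2NC(c2ccco2)C(C(=O)c2ccc(Cl)cc2)S3)cc(OC)c1OC`, compound 2 `COc1ccc(C(=O)C2Sc3nnc(-c4cc(OC)c(OC)c(OC)c4)n3NC2c2cccs2)cc1` and compound 3 `COc1ccc(C(=O)C2Sc3nnc(-c4cc(OC)c(OC)c(OC)c4)n3NC2c2ccco2)cc1` have been tested, while compound 4 `COc1cc(-c2nnc3n2NC(c2cccs2)C(C(=O)c2ccc(Cl)cc2)S3)cc(OC)c1OC` has not. In a functional assay on HepG2 cells (Homo sapiens) for cytotoxicity, read by MTT assay, with a stated time of 48 h (on this read-out lower numbers stand for stronger inhibition and higher numbers for weaker inhibition), compound 1 gives 78600 nM, and compound 2 gives 68000 nM. Compound 3 reaches only a limit of the assay, > 100000 nM, one of the values sitting at the limit of > 100000 nM in this assay, at which 1 of the 3 values shown sits. The cores of compound 2 and compound 4 differ from those of compound 1 and compound 3 by thiophen-2-yl in place of furan-2-yl on a saturated ring carbon. The change from compound 3 to compound 1 is chloro in place of methoxy on an aromatic carbon, and it made a step of an at least 1.2-fold lower number from compound 3 to compound 1 (0.10 log units; that floor lies within the scatter). The change from compound 2 to compound 4 is chloro in place of methoxy on an aromatic carbon, the same change at the same place. Because the step of an at least 1.2-fold lower number from compound 3 to compound 1 (0.10 log units; that floor lies within the scatter) starts from a limit and lies within the usual spread, for compound 4 the expected step is only a 1.1-fold lower number from compound 2 to compound 4 (0.05 log units; within the scatter). On that basis compound 4 is estimated to give about 60000 nM in this assay, most likely between 25000 nM and 140000 nM.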

Compound 4, half-maximal inhibitory concentration: 13200 nM
Compound 4: the middle estimate sits 4.5-fold (0.66 log units) above what was measured; the whole stated range lies above it.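

In this assay, chloro in place of methoxy on the 4-methoxyphenyl ring of compound 2 gives a 5.2-fold lower number from compound 2 to compound 4 (0.71 log units; beyond the scatter), and thiophen-2-yl in place of furan-2-yl gives a 6.0-fold lower number from compound 1 to compound 4 (0.77 log units; beyond the scatter). The chloro change lowers the number on both cores, which suggests its direction carries over, but this does not show that its size carries over, since the earlier step starts from the assay limit of compound 3: the same change on two cores in this assay, an at least 1.2-fold lower number (0.10 log units; that floor lies within the scatter) from compound 3 to compound 1 and a 5.2-fold lower number (0.71 log units; beyond the scatter) from compound 2 to compound 4; the limit leaves it open whether they differ The swap between furan-2-yl and thiophen-2-yl also points the same way on both cores, and its size is just as unsettled: the same change on two cores in this assay, an at least 1.4-fold higher number (0.16 log units; that floor lies within the scatter) from compound 2 to compound 3 and a 6.0-fold higher number (0.77 log units; beyond the scatter) from compound 4 to compound 1; the limit leaves it open whether they differ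

Going by these compounds, whether a fluoro, a methyl or an amine in the place of chloro would lower the number as chloro does remains open. On these data alone, it is also open whether a phenyl or a cyclohexyl group on the saturated ring carbon would behave like thiophen-2-yl or like furan-2-yl.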